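This account rests on a few compounds, and the source may have more. Where it says the series, first, only, none or still open, it means among the compounds named here.

Measured so far in a functional assay on U-87MG ATCC cells for cytotoxicity against U-87 MG (Homo sapiens), read by MTT assay, with a stated time of 72 h; a lower number here means a stronger inhibitor, a higher number a weaker inhibitor:
- compound 1 `COc1ccc2nc(NC(=O)c3cn(-c4ccccc4)nc3-c3ccccc3)sc2c1` gives 40600 nM
- compound 2 `Cc1ccc2nc(NC(=O)c3cn(-c4ccccc4)nc3-c3ccccc3)sc2c1` gives 23200 nM
- compound 3 `COc1ccc2nc(NC(=O)c3cn(-c4ccccc4)nc3-c3ccc(Cl)cc3)sc2c1` gives 21200 nM

The change from compound 1 to compound 2 is methyl in place of methoxy on an aromatic carbon; it gave a 1.8-fold lower number from compound 1 to compound 2 (0.24 log units; within the scatter). The core of compound 3 differs from that of compound 1 by chloro in place of hydrogen on an aromatic carbon, which gave a 1.9-fold lower number from compound 1 to compound 3 (0.28 log units; within the scatter). Compound 3 and compound 2 sit close to each other in this assay, and neither of the two steps from compound 1 is beyond the scatter.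

Compound 4 `Cc1ccc2nc(NC(=O)c3cn(-c4ccccc4)nc3-c3ccc(Cl)cc3)sc2c1` is not yet measured. It differs from compound 3 by methyl in place of methoxy on an aromatic carbon, the same change as that from compound 1 to compound 2, at the same place. Beside the earlier step of a 1.8-fold lower number from compound 1 to compound 2 (0.24 log units; within the scatter), the step of a 1.5-fold lower number from compound 3 to compound 4 (0.18 log units; within the scatter) is expected, resting on that single earlier instance only. Compound 4 is therefore estimated at 14000 nM, expected between 6000 nM and 35000 nM.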

Compound 4, half-maximal inhibitory concentration: 33200 nM
Beside the measured number, compound 4's estimate is 2.4-fold (0.38 log units) below it; low and high end bracket the measured number.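

In this assay, methyl in place of methoxy does not carry over as a fixed step from one core to the other, since on the chloro-bearing core it gave a 1.6-fold higher number from compound 3 to compound 4 (0.19 log units; within the scatter): the same change on two cores in this assay, a 1.8-fold lower number (0.24 log units; within the scatter) from compound 1 to compound 2 and a 1.6-fold higher number (0.19 log units; within the scatter) from compound 3 to compound 4, 2.7-fold (0.44 log units) apart, beyond the scatter of two such steps. Chloro in place of hydrogen shows the same behaviour, giving a 1.4-fold higher number from compound 2 to compound 4 (0.16 log units; within the scatter) on the core with methyl: the same change on two cores in this assay, a 1.9-fold lower number (0.28 log units; within the scatter) from compound 1 to compound 3 and a 1.4-fold higher number (0.16 log units; within the scatter) from compound 2 to compound 4, 2.7-fold (0.44 log units) apart, beyond the scatter of two such steps. For the compounds shown here, each single step lies within the scatter, so the four compounds show only that neither change transfers as a constant; they do not show why, nor which way either change would go on a further core.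

Still open, as far as these compounds go, is whether an amine, a carboxylic acid or a longer chain in place of the methoxy would give a step beyond the scatter. Also open, from the compounds shown here alone, is whether a bromo or a nitrile in place of the chloro would do so.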